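The source may report more compounds than this note shows. Statements on the series, on what has been measured and on what is new or still open speak of the compounds shown alone.

Compound 1 `CC1=CC[C@H]2[C@H](CC[C@]2(C)O)C(C)(C)[C@@H]1CC[C@H]1[C@]2(C)CC[C@H](OC(=O)c3ccc(C(F)(F)F)cc3)C(C)(C)O[C@H]2CC[C@@]1(C)O`: 23400 nM
Compound 2 `CC1=CC[C@H]2[C@H](CC[C@]2(C)O)C(C)(C)[C@@H]1CC[C@H]1[C@]2(C)CC[C@H](OC(=O)c3ccccc3Cl)C(C)(C)O[C@H]2CC[C@@]1(C)O`: 12100 nM

Both numbers come from a functional assay on MCF7 cells (Homo sapiens) for antiproliferative activity, read by MTT assay, with a stated time of 72 h; on this read-out higher numbers stand for weaker inhibition and lower numbers for stronger inhibition. Among the compounds with values here, with only two compounds measured, compound 2 can be compared with just one neighbour, and that comparison is a 1.9-fold lower number from compound 1 to compound 2 (0.29 log units; within the scatter). The two values therefore cannot be ranked. This step put 2-chlorophenyl in place of 4-(trifluoromethyl)phenyl on a carbonyl carbon.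

Compound 3 `CC1=CC[C@H]2[C@H](CC[C@]2(C)O)C(C)(C)[C@@H]1CC[C@H]1[C@]2(C)CC[C@H](OC(=O)c3ccccc3F)C(C)(C)O[C@H]2CC[C@@]1(C)O` has not been measured yet. It differs from compound 2 by a single exchange: fluoro in place of chloro on an aromatic carbon. This is fluoro in place of chloro on an aromatic carbon, ortho to a large group.

Within the data shown here, no measured step exchanges chloro for fluoro, so the step above is the only guide, and a loose one. It replaced a whole substituted phenyl group and still stayed within the scatter. No step beyond the scatter is therefore expected in this assay, and the expectation stays close to compound 2 at 12100 nM. The expected result is a 1.2-fold higher number from compound 2 to compound 3 (0.09 log units; within the scatter). For compound 3 the estimated value is 15000 nM, with an expected range of 7000 nM to 30000 nM.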

Compound 3, half-maximal inhibitory concentration: 11300 nM
The estimate for compound 3 lay 1.3-fold (0.12 log units) above the measured number; the range from low to high includes it.
By their numbers in this assay, from the lowest: compounds 3, 2 and 1 (each within the scatter of the next, the first and the last beyond it).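

In this assay, swapping chlorine for fluorine gives a 1.1-fold lower number from compound 2 to compound 3 (0.03 log units; within the scatter) and leaves no readable difference, so at this place, ortho to a large group, the two halogens cannot be told apart. Within the data shown here, the other new comparison, a 2.1-fold lower number from compound 1 to compound 3 (0.32 log units; beyond the scatter) for 2-fluorophenyl in place of 4-(trifluoromethyl)phenyl, is the first step in this small set to pass the scatter, but it is only modest and should not be over-read, since the matching step to the 2-chlorophenyl compound stayed within the scatter. Nothing measured here offers a reason for these small differences.

Because chloro and fluoro are the only groups tested at this place, the compounds shown cannot tell whether any halogen matters there, and a plain phenyl ring, a methoxy group or an amine at the same spot would be needed to test that. They also leave open whether a much larger change to the ester group, such as a carboxylic acid on the ring or a longer chain in place of the ring, would move the number further than these modest steps.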